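Bromo in place of methoxy on the shared core

The source may report more compounds than this note shows. Statements on the series, on what has been measured and on what is new or still open speak of the compounds shown alone.

compound 1 `Cc1ccc2[nH]c(COc3cccc(OCC4CCOCC4)c3)c(C)c(=O)c2c1` gives 38 nM
compound 2 `O=c1c(Cl)c(COc2cccc(OCC3CCOCC3)c2)[nH]c2ccccc12` gives 12 nM
compound 3 `COc1ccc2[nH]c(COc3cccc(OCC4CCOCC4)c3)c(C)c(=O)c2c1` gives > 10000 nM

All three values come from a functional assay on HUVEC cells (Homo sapiens) for inhibition, using NADPH, with a stated time of 2 h (a higher number here means a weaker inhibitor, a lower number a stronger inhibitor), as the only read-out. Compound 3 gives > 10000 nM as a limit of the assay and not as a number. Compound 3 thus stands at the limit of > 10000 nM in this assay, at which 1 of the 3 values shown sits, and has no exact place among the values.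

Compound 4 `Cc1c(COc2cccc(OCC3CCOCC3)c2)[nH]c2ccc(Br)cc2c1=O` carries bromo in place of methoxy on an aromatic carbon of compound 3 bromo in place of methoxy on an aromatic carbon and is otherwise unchanged. Among the compounds with values here, one measured step bears on that same carbon: an at least 260-fold higher number from compound 1 to compound 3 (2.42 log units; beyond the scatter) with methoxy in place of methyl. Within the data shown here, compound 2 is joined to the others by no step that differs in one place, so it serves only as background.

Methoxy is the group that compound 3 holds and compound 1 lacks, so a large step to a lower number is expected in this assay once it leaves, back toward compound 1 at 38 nM in this comparison. How closely bromo tracks methyl has not been measured, so the expected range is wide. The expected step is an at least 160-fold lower number from compound 3 to compound 4 (2.22 log units; beyond the scatter) as an estimate only. For compound 4 the estimated value is 60 nM with an expected range from 10 nM to 500 nM in this assay.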

Compound 4, half-maximal inhibitory concentration: 23 nM
The estimate for compound 4 lay 2.6-fold (0.42 log units) above the measured number; measured number inside the range.
By their numbers in this assay, from the lowest: compounds 2, 4 and 1 (each within the scatter of the next, the first and the last beyond it). At a limit, above all of these: compound 3.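

Within the data shown here, at this aromatic carbon the earlier compounds showed a single change, methoxy in place of methyl, and in this assay the exchange of methoxy for bromo now gives an at least 430-fold lower number from compound 3 to compound 4 (2.63 log units; beyond the scatter). Compound 3 stands at a limit of the assay and not at a number: the limit of > 10000 nM in this assay, at which 1 of the 4 values shown sits.

Bromo and methyl on this carbon cannot be told apart in this assay, with a 1.7-fold lower number from compound 1 to compound 4 (0.22 log units; within the scatter), so among the three groups seen at this place methoxy alone stands apart, and the earlier large step now reads as a feature of methoxy and not only as a contrast with methyl.

The compounds shown leave open how other groups would fall on this carbon: whether fluoro or ethyl would stay with methyl and bromo, and whether hydroxy, ethoxy or an amine would go with methoxy. Going by these compounds, they also leave open how far the true value of compound 3 lies past its limit, so the full size of both steps that start or end at it remains unknown.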